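Hydroxy added to the saturated ring of compound 2

A few compounds are considered here, and "the series" means these few. Any claim that something is new, unique, unknown or untested is made for them only; others in the source may bear on it.

Going by the values given here, compound 1 `COc1c(O)ccc(O)c1-c1cc(=O)c2c(O)cc(O)c(OC)c2o1` is the one member with a number: in an assay on HUVEC cells for inhibition of Trypsin (Homo sapiens), read by ELISA (on this read-out higher numbers stand for weaker inhibition and lower numbers for stronger inhibition), compound 1 gives 88000 nM. Compound 2 `O=C1C[C@@H](c2c(O)cccc2O)Oc2cc(O)cc(O)c21` returns only a limit in this assay, > 1000000 nM, and the limit of > 1000000 nM in this assay, at which 1 of the 2 values shown sits, marks where it stands. Compound 3 `O=C1c2c(O)cc(O)cc2O[C@H](c2c(O)cccc2O)[C@H]1O` carries hydroxy in place of hydrogen on a saturated ring carbon. Among the compounds with values here, no measured step of this kind exists, so the step of a number no higher from compound 2 to compound 3 (the limit leaves the size open) is expected to stay within the scatter, with no direction of its own. Compound 3 is expected to give 1000000 nM in this assay, estimated between 300000 nM and 3000000 nM, and a further limit is likely.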

Compound 3, half-maximal inhibitory concentration: > 1000000 nM
Compound 3: no number, only a limit; the forecaster's own chance of this, stated with the estimate: 70%; the middle value sits exactly at the limit.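

Going by these compounds alone, compound 2 and compound 3 both return only limits in this assay, and no step between them can be read. Going by these compounds, what hydroxy in place of hydrogen on a saturated ring carbon does to inhibition in this assay stays open.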